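The compounds below may be only part of what the source reports. "The series", "measured", "known", "first", "only" and "open" are said of these compounds alone.

Measured compounds:
Compound 1 `CCOC(=O)C[C@H]1[C@@H](O[Si](C)(C)C(C)(C)C)[C@H](n2cnc3c(NC(=O)Nc4ccccc4)ncnc32)O[C@@H]1COC(=O)NC` gives 3.09 nM in a functional assay on K562 cells (Homo sapiens) for antiproliferative activity; on this read-out higher numbers stand for weaker inhibition of growth and lower numbers for stronger inhibition of growth.
Compound 2 `CNC(=O)NC[C@H]1O[C@@H](n2cnc3c(NC(=O)Nc4ccccc4)ncnc32)[C@H](O[Si](C)(C)C(C)(C)C)[C@@H]1CC(=O)N(C)OC` gives 3.12 nM in this assay.

Compound 2 holds the higher of the two numbers seen so far, but its nearest neighbour, compound 1, sits within the usual scatter of it, so the two values show no real separation. Compound 3 `CCOC(=O)C[C@H]1[C@@H](O[Si](C)(C)C(C)(C)C)[C@H](n2cnc3c(NC(=O)Nc4ccccc4)ncnc32)O[C@@H]1CNC(=O)NC` has not yet been measured in this assay. It is set apart from compound 2 by a single change at the carbonyl carbon: ethoxy in place of methoxy(methyl)amino on a carbonyl carbon. Both measured compounds, which share the rest of the scaffold apart from this region, return almost the same value, so there is no shown step on which a large move could be based. The step from compound 2 to compound 3 is therefore expected to be small, a 1.1-fold higher number from compound 2 to compound 3 (0.05 log units; within the scatter), with no direction beyond the scatter. Compound 3 is accordingly estimated at 3.5 nM, with a likely range from 1.5 nM to 8 nM.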

Compound 3, concentration for 50% growth inhibition: 3.59 nM
Estimate against measurement, compound 3: 1.0-fold (0.01 log units) below; the measured number falls inside the stated range.
By their numbers in this assay, from the lowest: compounds 1, 2 and 3 (each within the scatter of the next).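

Among the compounds shown here, with compound 3, changes in one place can be read for the first time in this assay and ethoxy in place of methoxy(methyl)amino on a carbonyl carbon gives a 1.2-fold higher number from compound 2 to compound 3 (0.06 log units; within the scatter) and so leaves the two groups indistinguishable on this read-out. The second change, (methylcarbamoyl)amino in place of (methylcarbamoyl)oxy on a saturated chain carbon bound to a saturated ring carbon, gives a 1.2-fold higher number from compound 1 to compound 3 (0.07 log units; within the scatter) and likewise separates nothing, so each of the two places has now been varied once with no shift beyond the scatter. No measurement at hand offers an explanation for these results. What the compounds shown leave open is whether a carboxylic acid on that carbonyl carbon, or a longer chain in place of the ethoxy, would keep the number at this level. Equally open, on these data alone, is whether a free amine in place of the (methylcarbamoyl)amino would move it beyond the scatter.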